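This account rests on a few compounds, and the source may have more. Where it says the series, first, only, none or still open, it means among the compounds named here.

Measured compounds:
compound 1 `O=C1C[C@H](OCc2cn(-c3ccc([N+](=O)[O-])cc3)nn2)[C@H]2CO[C@@H]1O2` with 24800 nM in a functional assay on MDA-MB-231 cells (Homo sapiens) for cytotoxicity, read by MTT assay, with a stated time of 48 h; on this read-out lower numbers stand for stronger inhibition and higher numbers for weaker inhibition;
compound 2 `O=C1C[C@H](OCc2cn(-c3ccccc3)nn2)[C@H]2CO[C@@H]1O2` with 25200 nM.

Compound 2 gives the highest of the two numbers on this assay, but its nearest neighbour, compound 1, lies within the scatter: a 1.0-fold higher number from compound 1 to compound 2 (0.01 log units; within the scatter). The step to compound 3 `O=C1C[C@H](OCc2cn(C3CCCCC3)nn2)[C@H]2CO[C@@H]1O2` is cyclohexyl in place of phenyl on an aromatic nitrogen. Among the compounds with values here, the one measured step, from compound 1 to compound 2, concerns a different change on the phenyl and was flat; no measured step touches a change of the ring on the aromatic nitrogen itself. The two compounds at hand show that the aryl substituent could be altered without moving this assay, which is weak ground for any shift. Compound 3 is therefore expected to give about 26000 nM on this assay, in a range from 10000 nM to 65000 nM, a step of a 1.0-fold higher number from compound 2 to compound 3 (0.01 log units; within the scatter) that is expected to stay within the scatter.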

Compound 3, half-maximal inhibitory concentration: 24300 nM
For compound 3 the middle estimate is 1.1-fold (0.03 log units) above the measured one; the measured number falls inside the stated range.
By their numbers in this assay, from the lowest: compounds 3, 1 and 2 (each within the scatter of the next).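

In this assay, the step from an aromatic to a non-aromatic ring on the aromatic nitrogen, cyclohexyl in place of phenyl, gives a 1.0-fold lower number from compound 2 to compound 3 (0.02 log units; within the scatter). The earlier step changed only a substituent on the phenyl, whereas this one replaces the ring itself, and at this position the aromatic ring proves not to be required for a number at this level, at least for this pair of six-carbon rings. No measurement given here explains why the number stays level across this exchange.

All three compounds lie within the scatter of one another, so the compounds shown do not reveal which groups on this nitrogen, if any, would shift the number. From the compounds shown here alone, whether a longer alkyl chain, a primary amine or a carboxylic acid in that place would do so remains open.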